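The source may hold more compounds than are shown below. What is called first, only, known or untested is meant among the compounds shown, and "the series" means these compounds.

Working notes on the series. Of the compounds shown here, two have numbers so far in a functional assay on A2780 cells (Homo sapiens) for inhibition, read by MTT assay, with a stated time of 72 h; on this read-out lower numbers stand for stronger inhibition of growth and higher numbers for weaker inhibition of growth. Among the measured compounds shown here, compound 1 `COc1ccc(CNCCCNS(=O)(=O)c2cc(C(F)(F)F)cc(C(F)(F)F)c2)cc1OC` gives 3800 nM, and compound 2 `COc1ccc(CNCCCNS(=O)(=O)c2cc(C(F)(F)F)cc(C(F)(F)F)c2)cc1` gives 1700 nM, the lower of the two; the only measured step, a 2.2-fold lower number from compound 1 to compound 2 (0.35 log units; beyond the scatter), ran in the direction of stronger growth inhibition.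

Compound 3 `O=S(=O)(NCCCNCc1ccc(Cl)cc1)c1cc(C(F)(F)F)cc(C(F)(F)F)c1` is still to be measured in this assay. It differs from compound 2 by chloro in place of methoxy on an aromatic carbon. For the measured compounds named here, no measured step shows this exact exchange; the step from compound 1 to compound 2 bears on it only loosely, in that it also took a methoxy off an aromatic carbon and the number moved modestly. Taking that as the nearest guide, a small change is expected, most likely not beyond the scatter, with the direction uncertain. For compound 3 the expected step is a 1.2-fold lower number from compound 2 to compound 3 (0.08 log units; within the scatter), and the estimate in this assay is 1400 nM, within 600 nM to 3500 nM.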

Compound 3, concentration for 50% growth inhibition: 1800 nM
For compound 3 the middle estimate is 1.3-fold (0.11 log units) below the measured one, and the stated range covers the measured number.
By their numbers in this assay, from the lowest: compounds 2 and 3 (each within the scatter of the next); then compound 1.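

Chloro and methoxy, at the place para to a large group on the six-membered aromatic ring, cannot be told apart in this assay: a 1.1-fold higher number from compound 2 to compound 3 (0.02 log units; within the scatter). This exchange of one heavy atom for two therefore leaves the number unchanged within the scatter, and a hydrogen-bond acceptor on this group is not needed to hold it at this level, at least when chloro is the replacement. The shift away from the 3,4-dimethoxyphenyl compound also holds with chloro in the ring, a 2.1-fold lower number from compound 1 to compound 3 (0.32 log units; beyond the scatter), and no measurement at hand explains why these groups read alike.

As far as these compounds go, whether a quite different group at this place, such as an amine, a carboxylic acid or a nitrile, would move the number stays open. So does the effect of a longer chain in the shared core.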